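This account rests on a few compounds, and the source may have more. Where it says the series, first, only, none or still open, it means among the compounds named here.

In a physicochemical assay for solubility, in phosphate buffer, measured as kinetic solubility, with a stated time of 1 h, at pH 7.4 (on this read-out higher numbers stand for higher solubility and lower numbers for lower solubility), the measured compounds are:
compound 1 `CS(=O)(=O)Cc1cc(C2=CCOCC2)nc(-c2cccc(O)c2)n1`: 27 ug/mL
compound 2 `CNCC(=O)Nc1ccc(-c2nc(CS(C)(=O)=O)cc([C@@]34CCOC[C@@H]3C4)n2)cc1`: 167 ug/mL
compound 3 `Oc1cccc(-c2nccc(C3=CCOCC3)n2)c1`: 113 ug/mL

Compound 1, at 27 ug/mL, has the lowest number of the three. Compound 4 `CS(=O)(=O)Cc1cc([C@]23CCOC[C@H]2C3)nc(-c2cccc(O)c2)n1`, not yet measured, departs from it at one place: a group of 7 heavy atoms (6 carbon, 1 oxygen; one three-membered non-aromatic ring of carbon only, one six-membered non-aromatic ring with 1 hetero atom) in place of a group of 6 heavy atoms (5 carbon, 1 oxygen; one six-membered non-aromatic ring with 1 hetero atom), on an aromatic carbon. Going by the values given here, no measured step makes this exact change. Among the compounds with values here, the only measured step, a 4.2-fold higher number from compound 1 to compound 3 (0.62 log units; beyond the scatter), replaces the (methylsulfonyl)methyl group with hydrogen, so it concerns another place and bears on this change only indirectly. Compound 4 has the same entering group as compound 2, and compound 2 gives 167 ug/mL, but it also differs from compound 1 elsewhere, so it does not isolate this change. With such thin evidence, only a small upward move is expected in this assay, and none beyond the scatter. The expected step is a 1.4-fold higher number from compound 1 to compound 4 (0.15 log units; within the scatter). The estimate for compound 4 is 38 ug/mL, with an expected range from 15 ug/mL to 95 ug/mL.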

Compound 4, solubility: 75 ug/mL
Estimate against measurement, compound 4: 2.0-fold (0.30 log units) below; measured number inside the range.
By their numbers in this assay, from the lowest: compound 1; then compounds 4, 3 and 2 (each within the scatter of the next, the first and the last beyond it).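

Going by these compounds alone, until now, the only step read on the core of compound 1 concerned the (methylsulfonyl)methyl group. The result gives a first read in this assay at a second place, the aromatic carbon next to the ring nitrogen, with a 2.8-fold higher number from compound 1 to compound 4 (0.44 log units; beyond the scatter) for this exchange of groups, so this place too moves the number beyond the scatter. The two groups have equal counts of hydrogen-bond donors and acceptors and no net charge, and nothing measured here accounts for the rise.

The compounds shown carry only these two groups at this place, leaving open whether the rise follows the added three-membered ring or the lost double bond, which a plain tetrahydropyranyl group could separate. Going by these compounds, whether an amine or a carboxylic acid there would shift the number also remains open.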